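The source may hold more compounds than are shown below. What is called first, only, known or untested is meant among the compounds shown, and "the series" means these compounds.

Values measured so far in a functional assay on CNE-2 cells (Homo sapiens) for antiproliferative activity, read by sulforhodamine B assay, with a stated time of 48 h (on this read-out lower numbers stand for stronger inhibition and higher numbers for weaker inhibition), are these.

Compound 1 `O=C(/C=C/c1cccs1)c1ccccc1-c1ccc(F)cc1` gives 5900 nM
Compound 2 `COc1cc(C(=O)/C=C/c2ccccc2-c2ccc(F)nc2)ccc1O` gives 19000 nM
Compound 3 `COc1ccc(CNC(=O)c2ccccc2-c2ccc(F)cc2)cc1` gives > 50000 nM, which is a limit of the assay and not a number

Compound 1 and compound 2 both reach a real number in this assay, and those two readings are the only exact ones available. Compound 3 stands at the limit of > 50000 nM in this assay, at which 1 of the 3 values shown sits, and so has no number of its own.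

The next compound to be tested is compound 4 `COc1ccc(CNC(=O)c2ccccc2-c2ccc(F)cc2)cc1OC`. It is compound 3 with a single change (methoxy in place of hydrogen on an aromatic carbon), namely methoxy in place of hydrogen on an aromatic carbon, ortho to a methoxy group and meta to a large group.

Going by the values given here, no two measured compounds differ in only one place, so the data do not show what a change of this kind does. With so little to go on, the change expected in this assay is none beyond the scatter, or a small gain in inhibition. The estimated size of an at least 1.3-fold lower number from compound 3 to compound 4 (0.11 log units; that floor lies within the scatter) is correspondingly modest. The assay may well report only a limit again. If a number does appear, compound 4 is expected near 38000 nM, with an estimated range of 15000 nM to 50000 nM.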

Compound 4, half-maximal inhibitory concentration: > 50000 nM
Compound 4 ended at the assay's limit (the forecaster's own chance of this, stated with the estimate: 60%); middle value at least 1.3-fold (0.11 log units) away from the limit.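

Going by these compounds alone, compound 3 and compound 4 both end at a limit of the assay rather than at a number, so no step between them can be read in this assay, and the reading stands as: the limit of > 50000 nM in this assay, at which 2 of the 4 values shown sit. The compounds shown leave open whether methoxy in place of hydrogen on an aromatic carbon changes inhibition at all.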